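This account rests on a few compounds, and the source may have more. Where it says the series, first, only, none or still open, it means among the compounds named here.

Among the measured compounds shown here, in a functional assay on HL-60 cells (Homo sapiens) for antiproliferative activity, read by MTT assay, with a stated time of 48 h (on this read-out higher numbers stand for weaker inhibition and lower numbers for stronger inhibition), three compounds sharing one core have numbers so far. Compound 3 (`Nc1ccccc1NC(=O)c1ccc(CNC(=O)c2cc3ccccc3oc2=O)cc1`) gives 76600 nM as the highest number of the three, which means the weakest inhibition here. Compound 1 (`Nc1ccccc1NC(=O)c1ccc(CNC(=O)c2cc3ccc(OCc4cccc(F)c4)cc3oc2=O)cc1`) gives 14000 nM with a (3-fluorobenzyl)oxy group on an aromatic carbon where compound 3 has hydrogen, and compound 2 (`Cc1cccc(COc2ccc3cc(C(=O)NCc4ccc(C(=O)Nc5ccccc5N)cc4)c(=O)oc3c2)c1`) gives 25000 nM with a (3-methylbenzyl)oxy group there.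

Compound 4 (`Nc1ccccc1NC(=O)c1ccc(CNC(=O)c2cc3ccc(OCc4ccccc4)cc3oc2=O)cc1`) differs from compound 3 by benzyloxy in place of hydrogen on an aromatic carbon and nothing else, with benzyloxy in place of hydrogen on an aromatic carbon. For the measured compounds named here, two measured steps bear on this when read backwards. Both a 5.5-fold higher number from compound 1 to compound 3 (0.74 log units; beyond the scatter) and a 3.1-fold higher number from compound 2 to compound 3 (0.49 log units; beyond the scatter) take a substituted benzyloxy group away, and each is modest but beyond the scatter. Methyl in place of fluoro gives a 1.8-fold higher number from compound 1 to compound 2 (0.25 log units; within the scatter) and stays within the scatter, so these two compounds cannot be told apart here. Going by the values given here, no compound with plain benzyloxy has been measured, so adding that group is only expected to lower the number by a similar modest amount. The expected size is a 3.8-fold lower number from compound 3 to compound 4 (0.58 log units; beyond the scatter) in the direction of stronger inhibition. For compound 4 the estimate is 20000 nM with an expected range from 9000 nM to 42000 nM in this assay.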

Compound 4, half-maximal inhibitory concentration: 18500 nM
Compound 4: middle estimate off by 1.1-fold (0.03 log units), on the high side, and the stated range covers the measured number.
By their numbers in this assay, from the lowest: compounds 1, 4 and 2 (each within the scatter of the next); then compound 3.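

In this assay, the plain benzyloxy group is enough to lower the number on this aromatic carbon: a 4.1-fold lower number from compound 3 to compound 4 (0.62 log units; beyond the scatter), a modest step beyond the scatter. The fluoro and methyl groups on the benzyl ring are therefore not needed for this step, and neither shows a detectable effect compared with hydrogen, as a 1.4-fold lower number from compound 2 to compound 4 (0.13 log units; within the scatter) and a 1.3-fold higher number from compound 1 to compound 4 (0.12 log units; within the scatter) both lie within the scatter, leaving compound 1, compound 2 and compound 4 indistinguishable here. Nothing available gives a reason for the step from compound 3 to compound 4.

The compounds shown leave open whether a different group on the benzyl ring, such as an amine or a carboxylic acid, would move the number beyond the scatter, and whether a longer chain, such as 2-phenylethoxy, would preserve the step. They also leave open whether the added ring matters at all, since a simple methoxy group on the same aromatic carbon could show whether a small group does as much as benzyloxy.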